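The compounds below may be only part of what the source reports. "The series", "measured", "known", "first", "only" and "open" are said of these compounds alone.

Measured in a functional assay on the whole organism for inhibition, with Rattus norvegicus as the target; on this read-out lower numbers stand for an effect already at smaller amounts and higher numbers for an effect only at larger amounts of compound:
Compound 1 `CC(C)c1ccc(OC(C)(Cc2ccccc2)C(=O)O)cc1` gives > 10 mg/kg (a limit).
Compound 2 `CC(C)c1ccc(OC(C)(Cc2ccc(C(F)(F)F)cc2)C(=O)O)cc1` gives < 5 mg/kg (a limit).

Compound 1 has no number on this read-out. Its value of > 10 mg/kg is a limit, and it sits on the weaker side of the two results.

Compound 3 `CC(C)c1ccc(OC(C)(Cc2cccc(Cl)c2)C(=O)O)cc1` has chloro in place of hydrogen on an aromatic carbon, phenyl to 3-chlorophenyl, meta to a large group (chloro in place of hydrogen on an aromatic carbon).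

Going by the values given here, only one measured step bears on this change: an at least 2.0-fold lower number from compound 1 to compound 2 (0.30 log units; that floor lies within the scatter), with trifluoromethyl in place of hydrogen on an aromatic carbon. That step involves a different group and gives only a floor, so it offers weak support for the direction and none for the size.

A modest move to a lower number is therefore expected in this assay, and the assay may again return only a limit. The expected change is an at least 1.4-fold lower number from compound 1 to compound 3 (0.15 log units; that floor lies within the scatter). For compound 3 the estimate is 7 mg/kg, with an expected range of 3 mg/kg to 20 mg/kg.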

Compound 3, dose for half-maximal effect: 5 mg/kg
For compound 3 the middle estimate is 1.4-fold (0.15 log units) above the measured one; low and high end bracket the measured number.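

Chloro in place of hydrogen on an aromatic carbon, meta to a large group, gives an at least 2.0-fold lower number from compound 1 to compound 3 (0.30 log units; that floor lies within the scatter) in this assay. Going by these compounds alone, compound 3 is the first compound with a number rather than a limit, 5 mg/kg. It shows that a group other than trifluoromethyl on the phenyl also goes with a lower number, though that step is only a floor within the scatter. Compound 1 holds only a limit, so the size of this step stays unknown: the limit of > 10 mg/kg in this assay, at which 1 of the 3 values shown sits.

Compound 2 also holds only a limit, < 5 mg/kg, which leaves chloro and trifluoromethyl unranked. The compounds shown leave open whether a methoxy group or an amine in this place would shift the number the same way.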